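The compounds below may be only part of what the source reports. "The series", "measured", "known", "first", "only" and "open" are said of these compounds alone.

Compound 2 `CN(C)CCCCCSC1=Nc2ccccc2C(CC(=O)NCc2ccccc2)N1c1ccc(-c2ccccc2)cc1` gives 9600 nM in a functional assay on HCT-116 cells (Homo sapiens) for cytotoxicity, read by MTT assay, with a stated time of 48 h; a higher number here means a weaker inhibitor, a lower number a stronger inhibitor. Compound 1 `CN(C)CCCCCSC1=Nc2ccccc2C(CC(=O)NCc2ccccc2)N1c1ccc(-c2ccc(F)cc2)cc1` gives 9200 nM, and compound 3 `CN(C)CCCCCSC1=Nc2ccccc2C(CC(=O)NCc2ccc(F)cc2)N1c1ccc(-c2ccccc2)cc1` gives 6400 nM, so all three numbers lie within the scatter of one another and compound 2 cannot be set apart from them. The two measured steps, a 1.0-fold higher number from compound 1 to compound 2 (0.02 log units; within the scatter) and a 1.5-fold lower number from compound 2 to compound 3 (0.18 log units; within the scatter), both concern fluoro on an aromatic carbon and were each within the scatter. Compound 4 `O=C(CC1c2ccccc2N=C(SCCCCCN2CCCC2)N1c1ccc(-c2ccccc2)cc1)NCc1ccccc1` differs from compound 2 by pyrrolidin-1-yl in place of dimethylamino on a saturated chain carbon, five bonds along the chain from a sulfur. Among the compounds with values here, no measured step touches this amine, so nothing here bears directly on the change. The expected step is therefore a 1.1-fold lower number from compound 2 to compound 4 (0.03 log units; within the scatter), none beyond the scatter. Compound 4 is estimated at 9000 nM, with a range from 4000 nM to 20000 nM.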

Compound 4, half-maximal inhibitory concentration: 5500 nM
Compound 4: the middle estimate sits 1.6-fold (0.21 log units) above what was measured; low and high end bracket the measured number.
By their numbers in this assay, from the lowest: compounds 4, 3, 1 and 2 (each within the scatter of the next).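

In this assay, within the data shown here, the one step at this amine is a 1.7-fold lower number from compound 2 to compound 4 (0.24 log units; within the scatter) for pyrrolidin-1-yl in place of dimethylamino, on a saturated chain carbon, five bonds along the chain from a sulfur. Where the earlier steps concerned only fluoro on an aromatic carbon, this one shows that the end of the chain also takes a five-membered ring without a change beyond the scatter. Nothing measured here offers an explanation for this result.

From the compounds shown here alone, whether piperidin-1-yl, morpholin-4-yl, a primary amine or a shorter or longer chain would move the number beyond the scatter remains open. So does the outcome of pyrrolidin-1-yl combined with fluoro.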